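This account rests on a few compounds, and the source may have more. Where it says the series, first, only, none or still open, it means among the compounds named here.

Compound 2 `O=C(/C=C/c1ccc(N2CCCCC2)cc1)c1cc(Cl)sc1Cl` is one of two chalcone-type compounds with cytotoxicity data in an ADME assay on PBMC cells (Homo sapiens) for cytotoxicity, with a stated time of 5 days (on this read-out higher numbers stand for weaker inhibition and lower numbers for stronger inhibition), where compound 2 gives 42800 nM. Among the measured compounds shown here, its only comparator is compound 1 `Cc1ccc(C(=O)/C=C/c2ccc(N3CCCCC3)cc2)s1`, which in this assay gives 77800 nM; the two numbers sit next to each other, and the step of a 1.8-fold lower number from compound 1 to compound 2 (0.26 log units; within the scatter) does not separate them, so neither compound can be called the more or less cytotoxic of the pair. Compound 3 `O=C(/C=C/c1ccc(N2CCCCC2)cc1)c1ccc(I)s1` has not yet been measured. It differs from compound 2 only at the carbonyl carbon: 5-iodothiophen-2-yl in place of 2,5-dichlorothiophen-3-yl on a carbonyl carbon. For the measured compounds named here, the one measured step that bears on this change is the swap of one thiophene substituent for another at the same carbonyl carbon, a 1.8-fold lower number from compound 1 to compound 2 (0.26 log units; within the scatter), which stayed within the scatter. On that basis the exchange of one halogenated thiophene for another is expected to leave the number about where compound 2 stands, with a 1.2-fold higher number from compound 2 to compound 3 (0.07 log units; within the scatter) as the estimated step and no movement beyond the scatter foreseen. Compound 3 is therefore estimated at 50000 nM in this assay, with a range from 20000 nM to 125000 nM.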

Compound 3, half-maximal inhibitory concentration: > 100000 nM
Compound 3: a limit, no number; the forecaster's own chance of this, stated with the estimate: 10%; at least 2.0-fold (0.30 log units) between middle value and limit.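

In this assay compound 3 stands as a limit of the assay, not a number: the limit of > 100000 nM in this assay, at which 1 of the 3 values shown sits.

Among the compounds shown here, replacing 2,5-dichlorothiophen-3-yl with 5-iodothiophen-2-yl on a carbonyl carbon gives an at least 2.3-fold higher number from compound 2 to compound 3 (0.36 log units; beyond the scatter) and is the first step to clear the scatter, so the group at this position can shift the read-out, which the earlier pair could not show. The other step, with iodo in place of methyl on an aromatic carbon, is an at least 1.2-fold higher number from compound 1 to compound 3 (0.10 log units; that floor lies within the scatter) and as a floor does not by itself separate those two compounds, though the limit leaves their true distance unknown.

The change from compound 2 to compound 3 alters the halogen, the number of halogens and the point of attachment on the thiophene all at once, so the compounds shown cannot assign the shift to any one of these. From the compounds shown here alone, a 5-chlorothiophen-2-yl group on the same carbonyl carbon would separate the identity of the halogen from the attachment point, and how far compound 3 really lies from the others stays open while its value is only a limit.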